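The source may hold more compounds than are shown below. What is called first, only, known or untested is meant among the compounds shown, and "the series" means these compounds.

The measured compounds: compound 1 `C=C1C(=O)[C@]23C[C@@]1(O)CC[C@H]2c1ccc(O)c(C)c1[C@@H]3Cn1cc(-c2ccc(C(F)(F)F)cc2)nn1`, compound 2 `C=C1C(=O)[C@]23C[C@@]1(O)CC[C@H]2c1ccc(O)c(C)c1[C@@H]3Cn1cc(-c2ccc(C)cc2)nn1`, compound 3 `Cc1ccc(-c2cn(C[C@H]3c4c(ccc(OS(=O)(=O)c5ccc(C)cc5)c4C)[C@@H]4CC[C@@]5(C)C[C@]43CC5=O)nn2)cc1`.

In a functional assay on HL-60 cells (Homo sapiens) for cytotoxicity, read by MTT assay, with a stated time of 4 days (on this read-out higher numbers stand for weaker inhibition and lower numbers for stronger inhibition), compound 1 gives 720 nM. In this assay compound 2 gives 830 nM. For compound 3 this assay reports only a limit, > 20000 nM. Compound 1 and compound 2 differ in one place, (trifluoromethyl in place of methyl on an aromatic carbon), and the step of a 1.2-fold lower number from compound 2 to compound 1 (0.06 log units; within the scatter). Compound 4 `Cc1ccc(S(=O)(=O)Oc2ccc3c(c2C)[C@H](Cn2cc(-c4ccc(C(F)(F)F)cc4)nn2)[C@@]24CC(=O)[C@@](C)(CC[C@@H]32)C4)cc1` is not yet measured; it carries the same change relative to compound 3, (trifluoromethyl in place of methyl on an aromatic carbon). The difference between the core of compound 3 and the core of compound 2 is not broken down here. Because compound 3 sits at the limit of > 20000 nM in this assay, at which 1 of the 3 values shown sits, and because the same change gave a 1.2-fold lower number from compound 2 to compound 1 (0.06 log units; within the scatter), compound 4 is expected to remain near that limit. The expected step is a step that the limit leaves unreadable from compound 3 to compound 4. Compound 4 is estimated at 25000 nM, between 8000 nM and 80000 nM.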

Compound 4, half-maximal inhibitory concentration: > 20000 nM
Compound 4 ended at the assay's limit; the forecaster's own chance of this, stated with the estimate: 75%; the middle value lies beyond the limit too.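

Going by these compounds alone, compound 3 and compound 4 are both reported only as limits, and no step between them can be read. Going by these compounds, whether trifluoromethyl in place of methyl changes anything on the core of compound 3 remains open.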